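Urea analogue of compound 3: expected inhibition on the cell assay

A few compounds are considered here, and "the series" means these few. Any claim that something is new, unique, unknown or untested is made for them only; others in the source may bear on it.

Measured so far in a functional assay on HL-60 cells (Homo sapiens) for inhibition, read by CCK-8 assay, with a stated time of 48 h; a higher number here means a weaker inhibitor, a lower number a stronger inhibitor:
- compound 1, `COc1cccc(NC(=S)NCCNS(=O)(=O)c2ccc(-c3ccccc3Oc3ccc([N+](=O)[O-])cc3)s2)c1`: compound 1 reaches only the assay limit, > 50000 nM.
- compound 2, `COc1ccc(NC(=S)NCCNS(=O)(=O)c2sccc2-c2ccc(C)cc2Oc2ccc(O)c(O)c2)cc1`: compound 2 gives 4100 nM.
- compound 3, `Cc1ccc(-c2ccsc2S(=O)(=O)NCCNC(=S)Nc2ccc([N+](=O)[O-])cc2)c(Oc2ccc(O)c(O)c2)c1`: compound 3 gives 2900 nM.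

Among the compounds with values here, compound 3 holds the lowest of the two numbers in this assay, with compound 2 as its nearest neighbour; the one measured step, a 1.4-fold lower number from compound 2 to compound 3 (0.15 log units; within the scatter), lies within the scatter, so the two are not separated. Compound 1 is a limit only, (the limit of > 50000 nM in this assay, at which 1 of the 3 values shown sits), and gives no number to compare.

Compound 4, `Cc1ccc(-c2ccsc2S(=O)(=O)NCCNC(=O)Nc2ccc([N+](=O)[O-])cc2)c(Oc2ccc(O)c(O)c2)c1`, is to be measured in this assay. It differs from compound 3 in one place: a group of 12 heavy atoms (7 carbon, 2 nitrogen, 3 oxygen; one six-membered aromatic ring of carbon only) in place of a group of 12 heavy atoms (7 carbon, 2 nitrogen, 2 oxygen, 1 sulfur; one six-membered aromatic ring of carbon only), on an amine nitrogen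

Within the data shown here, no measured step touches this part of the molecule. Among the measured compounds shown here, the only step in hand, a 1.4-fold lower number from compound 2 to compound 3 (0.15 log units; within the scatter), concerns a change on an aromatic carbon elsewhere and was itself within the scatter, so it gives no direction for the present change. With nothing to point either way, the number for compound 4 is expected close to that of compound 3, and the expected step of a 1.2-fold higher number from compound 3 to compound 4 (0.08 log units; within the scatter) is taken as none beyond the scatter, with a wide band to cover the untested change.

The estimate for compound 4 in this assay is 3500 nM, within a range from 900 nM to 15000 nM.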

Compound 4, half-maximal inhibitory concentration: 3900 nM
Compound 4: the middle estimate sits 1.1-fold (0.05 log units) below what was measured; the range from low to high includes it.
By their numbers in this assay, from the lowest: compounds 3, 4 and 2 (each within the scatter of the next). At a limit, above all of these: compound 1.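

Within the data shown here, the exchange of sulfur for oxygen on the amine nitrogen, with the 4-nitrophenyl ring kept, is the first change read at this position, and in this assay it gives a 1.3-fold higher number from compound 3 to compound 4 (0.13 log units; within the scatter). For this pair, the thiourea sulfur is therefore not needed to hold the number at the level of compound 3, and the urea and thiourea are not separated. The wider exchange at the same position, with (4-nitrophenyl)carbamoyl entering in place of the group that carries the methoxyphenyl ring and the sulfur, gives a 1.1-fold lower number from compound 2 to compound 4 (0.02 log units; within the scatter), so this change does not separate its two compounds either.

No measurement shown offers an explanation for these results at this position. The compounds shown leave open whether an amide or a guanidine in place of the urea, or a longer chain on the amine nitrogen, would stay at this level, and whether the urea would match the thiourea with a ring other than 4-nitrophenyl, such as the methoxyphenyl ring of compound 2.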